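The source may report more compounds than this note shows. Statements on the series, on what has been measured and on what is new or still open speak of the compounds shown alone.

Working notes on the series in an assay on CHO cells for displacement of a labelled ligand from adenosine receptor A1 (Homo sapiens), read by scintillation counting, tested at 10 uM; on this read-out higher numbers stand for more inhibition at the one concentration tested (going by the name of the read-out) and lower numbers for less inhibition.

Of the compounds shown here, three are measured so far. Compound 1 `Cc1c(-c2ccccc2)sc(N)c1C(=O)c1ccc(Cl)cc1` carries a phenyl on the core and gives 1% in this assay. Compound 2 `CC(C)(C)Cc1c(-c2ccncc2)sc(N)c1C(=O)c1ccc(Cl)cc1` carries a pyridin-4-yl and a neopentyl group on the core and gives 1%. Compound 3 `CC(C)(C)Cc1c(-c2ccccn2)sc(N)c1C(=O)c1ccc(Cl)cc1` carries a pyridin-2-yl in place of the pyridin-4-yl and gives 1%. Within the data shown here, on these numbers compound 2 stands level with compound 1 and with compound 3; the only one-place step among them, no change at the digits printed from compound 2 to compound 3 (within the scatter), stays within the scatter. Nothing in this set rises above a flat reading.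

Compound 4 `Cc1cccc(-c2sc(N)c(C(=O)c3ccc(Cl)cc3)c2CC(C)(C)C)c1` is not yet measured in this assay. It differs from compound 2 in one place: 3-methylphenyl in place of pyridin-4-yl on an aromatic carbon. The measured step that bears on this change is the swap of one six-membered ring for another, no change at the digits printed from compound 2 to compound 3 (within the scatter), and compound 1, which already carries a carbon-only ring, gives 1%. No listed compound shows any displacement in this assay.

For compound 4 the step of a number 1 percentage points higher from compound 2 to compound 4 (within the scatter) is therefore expected to stay within the scatter, because compound 1 gives 1% with a carbon-only ring in the same position. The estimate for compound 4 is 2%, with a range from -8% to 12%.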

Compound 4, a percentage reported as inhibition, at one concentration (the size of the read-out at that concentration, not a potency): 1%
The estimate for compound 4 lay 1 percentage points above the measured number, and the stated range covers the measured number.
By their numbers in this assay, from the lowest: compounds 1, 2, 3 and 4 (each within the scatter of the next).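

Replacing pyridin-4-yl with 3-methylphenyl on the aromatic carbon next to the ring sulfur, with the neopentyl group kept, gives in this assay no more than the printed step: no change at the digits printed from compound 2 to compound 4 (within the scatter). Replacing pyridin-2-yl with the same group reads the same way: no change at the digits printed from compound 3 to compound 4 (within the scatter). Among these compounds, until now, the only one-place change read with the neopentyl group in place was between two rings with a hetero atom, whereas these steps add a six-membered aromatic ring of carbon only, bearing a methyl, and the reading stays flat; with every compound at the same level, the series gives no sign of which groups at this position matter, and no measurement on hand accounts for the flat reading.

Still open, on these data alone, is whether any group at this position lifts the reading off this level, for example a phenyl ring bearing a carboxylic acid or a primary amine. Also open, as far as these compounds go, is whether a longer chain in place of the neopentyl group, or a change to the amino group on the shared core, would move the number at all.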